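The source may hold more compounds than are shown below. What is called first, only, known or untested is meant among the compounds shown, and "the series" means these compounds.

Compound 1 `CCN(CC)Cc1cc(Br)c(S(C)(=O)=O)cc1C(=O)N=C(N)N`: 9500 nM
Compound 2 `Cc1cc(C)c(S(C)(=O)=O)cc1C(=O)N=C(N)N`: 11 nM
Compound 3 `Cc1cc(-c2cc(C(F)(F)F)cc(C(F)(F)F)c2)c(S(C)(=O)=O)cc1C(=O)N=C(N)N`: 2800 nM

In a functional assay for inhibition of sodium/hydrogen exchanger (Oryctolagus cuniculus) (on this read-out higher numbers stand for weaker inhibition and lower numbers for stronger inhibition), compound 2 gives the lowest number of the three, and both other compounds lie well beyond the usual scatter from it: compound 3 gives 2800 nM and compound 1 gives 9500 nM. Compound 4 `CSc1cc(C)c(C(=O)N=C(N)N)cc1S(C)(=O)=O` is not yet measured. It differs from compound 2 in one place: methylsulfanyl in place of methyl on an aromatic carbon. Among the measured compounds shown here, no measured pair shows this exact change, so the expectation rests on the pattern that compound 2, with the smallest groups on the shared core, is far stronger than compound 1 and compound 3, which carry larger groups there. A moderate weakening is therefore expected, with the step from compound 2 to compound 4 estimated at a 5.5-fold higher number from compound 2 to compound 4 (0.74 log units; beyond the scatter). Compound 4 is expected to give about 60 nM, within a range of 15 nM to 400 nM.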

Compound 4, half-maximal inhibitory concentration: 6 nM
Compound 4: middle estimate off by 10-fold (1.00 log units), on the high side; measured number outside the range, below it.
By their numbers in this assay, from the lowest: compounds 4 and 2 (each within the scatter of the next); then compound 3; then compound 1.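

In this assay, methylsulfanyl in place of methyl gives a 1.8-fold lower number from compound 2 to compound 4 (0.26 log units; within the scatter), so the two compounds cannot be told apart. A group larger than methyl can therefore sit on this aromatic carbon, ortho to a methylsulfonyl group, without leaving the scatter of compound 2. Nothing at hand explains why the two compounds match. On these data alone, whether a methoxy group or an amine on this carbon would behave the same way remains open. So does the effect of a longer chain on the sulfur, such as ethylsulfanyl.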